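The source may hold more compounds than are shown below. What is called first, only, known or untested is meant among the compounds shown, and "the series" means these compounds.

The measured compounds: compound 1 `Cc1cc(O)c(C(C)C)cc1-c1cc(-c2cccs2)c(C#N)c(=O)[nH]1` gives 68% in a functional assay for inhibition, tested at 100 ug/mL; a lower number here means a weaker effect, a higher number a stronger effect of the compound at the concentration tested; compound 2 `COc1cc(-c2cc(-c3cc(C(C)C)c(O)cc3C)[nH]c(=O)c2C#N)ccc1O` gives 44%.

Compound 2 stands lowest of the two numbers, and the step of a number 24 percentage points lower from compound 1 to compound 2 (beyond the scatter) is the only one measured. Compound 3 `Cc1cc(O)c(C(C)C)cc1-c1cc(-c2ccco2)c(C#N)c(=O)[nH]1` is not yet measured. It differs from compound 2 as follows: furan-2-yl in place of 4-hydroxy-3-methoxyphenyl on an aromatic carbon. Compound 3 thus carries furan-2-yl where compound 1 carries thiophen-2-yl, so the step from compound 2 to compound 3 largely retraces the measured step in the opposite direction. Because a number 24 percentage points lower from compound 1 to compound 2 (beyond the scatter) was a modest drop beyond the scatter, a rise of similar size is expected for compound 3, about a number 18 percentage points higher from compound 2 to compound 3 (beyond the scatter). Compound 3 is therefore estimated to give 62% in this assay, with a range from 42% to 78%.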

Compound 3, a percentage reported as inhibition, at one concentration (the size of the read-out at that concentration, not a potency): 70%
The estimate for compound 3 lay 8 percentage points below the measured number; the measured number falls inside the stated range.
By their numbers in this assay, from the lowest: compound 2; then compounds 1 and 3 (each within the scatter of the next).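

In this assay, placing furan-2-yl opposite the ring nitrogen in place of 4-hydroxy-3-methoxyphenyl gives a number 26 percentage points higher from compound 2 to compound 3 (beyond the scatter), so the lower number of compound 2 is not a fixed feature of the shared core. Exchanging thiophen-2-yl for furan-2-yl gives a number 2 percentage points higher from compound 1 to compound 3 (within the scatter), so this assay does not separate these two five-membered rings at this position. Among these three compounds, both five-membered rings stand beyond the scatter from the one six-membered ring, though no measurement shown bears on a cause for these steps.

The compounds shown leave open whether the lower number of compound 2 goes with its six-membered ring or with its hydroxy and methoxy groups, which a plain phenyl here would separate. Going by these compounds, how a pyrrol-2-yl or a morpholine would fare at this position also remains open.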